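The source may hold more compounds than are shown below. What is called first, only, known or untested is meant among the compounds shown, and "the series" means these compounds.

Three compounds share one core and differ only in the chain attached to it. Compound 1 `CCc1onc(NS(=O)(=O)c2ccc(C(C)(C)C)cc2)c1Sc1cccc(OC)c1` carries a plain ethyl chain, and in an assay on A7R5 cells for displacement of a labelled ligand from Endothelin-1 receptor (Rattus norvegicus) (on this read-out higher numbers stand for weaker inhibition and lower numbers for stronger inhibition), compound 1 gives 800 nM. Compound 2 `COc1cccc(Sc2c(NS(=O)(=O)c3ccc(C(C)(C)C)cc3)noc2CCC/C=N/O)c1` extends that chain, and in this assay compound 2 gives 1500 nM. Compound 3 `COc1cccc(Sc2c(NS(=O)(=O)c3ccc(C(C)(C)C)cc3)noc2CCO)c1` bears a hydroxy group on the chain, and in this assay compound 3 gives 770 nM. The steps among them are all modest: a 1.9-fold higher number from compound 1 to compound 2 (0.27 log units; within the scatter), a 1.0-fold lower number from compound 1 to compound 3 (0.02 log units; within the scatter) and a 1.9-fold lower number from compound 2 to compound 3 (0.29 log units; within the scatter). Compound 3 thus holds the lowest of the three numbers, yet its gaps to compound 1 and to compound 2 stay within the scatter, so no order among them can be read.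

Compound 4 `COc1cccc(Sc2c(NS(=O)(=O)c3ccc(C(C)(C)C)cc3)noc2CCCC(C)=O)c1` is the next member. The change is 2-oxopropyl in place of hydroxy on a saturated chain carbon, two bonds along the chain from an aromatic carbon. The step that bears most on this change is the one that also added heavy atoms at the same place on the chain, a 1.9-fold higher number from compound 1 to compound 2 (0.27 log units; within the scatter), which stayed within the scatter; the reverse kind of change, a 1.9-fold lower number from compound 2 to compound 3 (0.29 log units; within the scatter), was also small. On that basis the step is expected to be modest, with no clear direction beyond the scatter, and is estimated as a 1.3-fold higher number from compound 3 to compound 4 (0.11 log units; within the scatter). Compound 4 is therefore expected to give about 1000 nM in this assay, with a likely range from 400 nM to 2500 nM.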

Compound 4, half-maximal inhibitory concentration: 1300 nM
Estimate against measurement, compound 4: 1.3-fold (0.11 log units) below; the measured number falls inside the stated range.
By their numbers in this assay, from the lowest: compounds 3, 1, 4 and 2 (each within the scatter of the next).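

Setting 2-oxopropyl in place of hydroxy removes the hydrogen-bond donor and keeps one hydrogen-bond acceptor, and in this assay this exchange gives only a small step (a 1.7-fold higher number from compound 3 to compound 4 (0.23 log units; within the scatter)), so the donor count at this place on the chain does not separate these two chains on this read-out. The longer chain ending in a carbonyl also stays within the scatter of the plain ethyl chain (a 1.6-fold higher number from compound 1 to compound 4 (0.21 log units; within the scatter)) and of the chain ending in the oxime-type group (a 1.2-fold lower number from compound 2 to compound 4 (0.06 log units; within the scatter)), which means that all four chains now shown fall together, with no order among them, and that this position has so far tolerated every chain placed on it. Nothing at hand explains these small steps.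

On these data alone, what remains open is whether any group at this place can move the number beyond the scatter at all, for example an amine or a carboxylic acid at the end of the chain, or a ring in place of the chain. As far as these compounds go, it is equally open whether a chain longer than 3-acetylpropyl would still leave the number where these four compounds stand.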